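Sulfanyl to sulfonyl: compound 3 to compound 4

This account rests on a few compounds, and the source may have more. Where it says the series, first, only, none or still open, it means among the compounds named here.

compound 1 `O=C(/C(=C\c1c(O)cc(O)cc1O)SCc1ccc(Cl)c(Cl)c1)c1ccc(Cl)cc1` gives 25000 nM
compound 2 `COc1ccc(/C=C(\C(=O)c2ccc(Cl)cc2)S(=O)(=O)c2ccc(Br)cc2)cc1O` gives 10000 nM
compound 3 `O=C(/C(=C\c1c(O)cc(O)cc1O)Sc1ccc(Br)cc1)c1ccc(Cl)cc1` gives 50000 nM

All three values come from a functional assay on DU-145 cells (Homo sapiens) for inhibition, read by trypan blue exclusion, with a stated time of 96 h (on this read-out lower numbers stand for stronger inhibition of growth and higher numbers for weaker inhibition of growth), as the only read-out. Compound 3 sits with compound 1 at the upper end of the range, while compound 2 lies lower, beyond the scatter. Compound 4 `O=C(/C(=C\c1c(O)cc(O)cc1O)S(=O)(=O)c1ccc(Br)cc1)c1ccc(Cl)cc1` carries (4-bromophenyl)sulfonyl in place of (4-bromophenyl)sulfanyl on a double-bonded chain carbon bound to a carbonyl carbon and a double-bonded chain carbon. Going by the values given here, the one measured step, a 2.0-fold higher number from compound 1 to compound 3 (0.30 log units; within the scatter), changes another group on the sulfur and does not test this change. Among the compounds with values here, the only hint is compound 2, which has the same sulfonyl group on a different core and gives 10000 nM as its value. A modest expected move to a lower number is therefore a 2.5-fold lower number from compound 3 to compound 4 (0.40 log units; beyond the scatter) as a tentative call. For compound 4 the estimate is 20000 nM (expected range 5000 nM to 60000 nM).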

Compound 4, concentration for 50% growth inhibition: > 100000 nM
Compound 4 was reported as a limit; the forecaster's own chance of this, stated with the estimate: 10%; middle value at least 5.0-fold (0.69 log units) from the limit.
By their numbers in this assay, from the lowest: compound 2; then compounds 1 and 3 (each within the scatter of the next). At a limit, above all of these: compound 4.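

In this assay compound 4 stands only as a limit: the limit of > 100000 nM in this assay, at which 1 of the 4 values shown sits.
On the double-bonded chain carbon, (4-bromophenyl)sulfonyl in place of (4-bromophenyl)sulfanyl gives no gain: the change reads as (an at least 2.0-fold higher number from compound 3 to compound 4 (0.30 log units; that floor lies within the scatter)), so the printed floor alone shows no loss beyond the scatter. The lower number of compound 2 does not carry over to the trihydroxyphenyl compound 4, with (an at least 10-fold higher number from compound 2 to compound 4 (1.00 log units; beyond the scatter)) for the aryl change and (an at least 4.0-fold higher number from compound 1 to compound 4 (0.60 log units; beyond the scatter)) for the change on the sulfur.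

On these data alone, the full size of all three steps stays open at this limit. Also open, as far as these compounds go, is whether a sulfinyl group at this carbon, or an amine in place of the bromine, would keep growth inhibition.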